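This account rests on a few compounds, and the source may have more. Where it says the series, first, only, none or still open, it means among the compounds named here.

In a functional assay on cells for agonist activity at Free fatty acid receptor 1 (Mus musculus), read by FLIPR and calcium flux, with a stated time of 5 min (on this read-out lower numbers stand for smaller maximal responses and higher numbers for larger maximal responses), compound 1 `Cc1nn(-c2ccccn2)c2cc(-c3ccc(CCC(=O)O)cc3)ccc12` gives 95%, the lowest of two numbers, and compound 2 `COc1nn(-c2ccccn2)c2cc(-c3ccc(CCC(=O)O)cc3)ccc12` gives 96%; the two differ by a number 1 percentage points higher from compound 1 to compound 2 (within the scatter). Compound 3 `Cc1nn(-c2ccccn2)c2cc(-c3ccc([C@@H]4C[C@H]4C(=O)O)cc3)ccc12` differs from compound 1 by 2-carboxycyclopropyl in place of 2-carboxyethyl on an aromatic carbon. Going by the values given here, no measured step bears on this change, since the only step on record concerns a methoxy in place of a methyl and stays within the scatter. Compound 3 is therefore expected to show a number 2 percentage points lower from compound 1 to compound 3 (within the scatter), with an estimated efficacy of 93%, ranging from 80% to 105%.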

Compound 3, largest response reached (reported as efficacy), in percent of the reference or control that the assay uses: 2%
For compound 3 the middle estimate is 91 percentage points above the measured one; measured number below the stated range.
By their numbers in this assay, from the lowest: compound 3; then compounds 1 and 2 (each within the scatter of the next).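

In this assay, 2-carboxycyclopropyl in place of 2-carboxyethyl, on an aromatic carbon para to a large group, gives a number 93 percentage points lower from compound 1 to compound 3 (beyond the scatter). This shows that the maximal response is highly sensitive to the change at this position, which the earlier step, a number 1 percentage points higher from compound 1 to compound 2 (within the scatter), made at another place, could not show. Nothing on hand accounts for this result. The compounds shown do not separate the role of the three-membered ring from that of its two defined stereocentres. As far as these compounds go, how the opposite stereoisomer of 2-carboxycyclopropyl or a longer chain such as 3-carboxypropyl would respond remains open.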